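Swapping One Aryl Group for Another on a Shared Core

The source may hold more compounds than are shown below. What is called first, only, known or untested is meant among the compounds shown, and "the series" means these compounds.

Going by the values given here, compound 2 `O=c1oc2ccccc2c(N2CCN(c3ccc(Cl)c(Cl)c3)CC2)c1CO` is the only compound here with a measured number: in a functional assay on WM1361 cells (Homo sapiens) for inhibition, read by MTT assay, with a stated time of 24 h (a higher number here means a weaker inhibitor, a lower number a stronger inhibitor), compound 2 gives 42700 nM. Compound 1 `CCN1CCN(c2c(CO)c(=O)oc3ccccc23)CC1` gives > 100000 nM in this assay, which is a limit of the assay rather than a number. Among the compounds with values here, the one measured step, an at least 2.3-fold lower number from compound 1 to compound 2 (0.36 log units; beyond the scatter), is at least modest. Compound 3 `COc1ccccc1N1CCN(c2c(CO)c(=O)oc3ccccc23)CC1` differs from compound 2 by 2-methoxyphenyl in place of 3,4-dichlorophenyl on an amine nitrogen in a ring. Both groups are aromatic rings, so that step offers little guidance on direction, and no change beyond the scatter is expected, with wide uncertainty. Compound 3 is expected to give 60000 nM in this assay, ranging from 20000 nM to 150000 nM. The expected step is a 1.4-fold higher number from compound 2 to compound 3 (0.15 log units; within the scatter).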

Compound 3, half-maximal inhibitory concentration: > 50000 nM
Compound 3 ended at the assay's limit (the forecaster's own chance of this, stated with the estimate: 35%); the middle value does not contradict the limit.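

Compound 3 gives no true number, only a limit of the assay: the limit of > 50000 nM in this assay, at which 1 of the 3 values shown sits. Going by these compounds, the step is an at least 1.1-fold higher number from compound 2 to compound 3 (0.06 log units; that floor lies within the scatter), so swapping 3,4-dichlorophenyl for 2-methoxyphenyl on this nitrogen shows that one aromatic ring cannot simply stand in for another with a known result, and the true size of the change stays unknown. Compound 1 and compound 3 both end at limits, so the step between them cannot be read.

The compounds shown leave open whether a plain phenyl or a benzyl group on this nitrogen would give a measurable number.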